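The compounds below may be only part of what the source reports. "The series", "measured", "known", "first", "only" and "open" are said of these compounds alone.

Compounds measured:

compound 1 `CN1CCN(CCCNC(=O)n2c(=O)n(C3CC3)c3ccccc32)CC1` — 6.4
compound 2 `CC(C)n1c(=O)n(C(=O)NCCN2CCN(C)CC2)c2cc(F)ccc21` — 6.88
compound 3 `CCn1c(=O)n(C(=O)NCCN2CCN(C)CC2)c2ccccc21` — 6.79

In a functional assay for antagonist activity at 5-hydroxytryptamine receptor 4 (Cavia porcellus) (on this read-out higher numbers stand for higher potency (the scale is a negative logarithm) and lower numbers for lower potency), compound 3 lies close to compound 2, the two values falling within the scatter of one another, while it stands clearly above compound 1, that gap lying beyond the scatter.

Compound 4 `CN1CCN(CCNC(=O)n2c(=O)[nH]c3ccccc32)CC1` has not yet been measured in this assay. It differs from compound 3 in one place: hydrogen in place of ethyl on an aromatic nitrogen. Among the measured compounds shown here, no measured pair shows this change directly, so its effect cannot be read from the data. The account nonetheless expects a modest loss in this assay, the step of a number 0.49 log units lower from compound 3 to compound 4 (beyond the scatter) being estimated as moderate and downward. For compound 4 the estimated value is 6.3, with a range from 5.7 to 6.9.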

Compound 4, negative logarithm of the antagonist equilibrium constant: < 6
Compound 4: only a limit was reported; the forecaster's own chance of this, stated with the estimate: 5%; at least 0.30 log units between middle value and limit.
By their numbers in this assay, from the lowest: compound 1; then compounds 3 and 2 (each within the scatter of the next). At a limit, below all of these: compound 4.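

In this assay compound 4 gives < 6, which is a limit and not a number. Hydrogen in place of ethyl on the aromatic nitrogen comes with a number at least 0.79 log units lower from compound 3 to compound 4 (beyond the scatter), the first direct reading of this position, where every earlier compound carries a carbon group, and it shows that the ethyl cannot be removed without a loss of potency. The size of that loss remains only a bound: the limit of < 6 in this assay, at which 1 of the 4 values shown sits. The compounds shown leave open whether a smaller methyl or a longer propyl chain on this nitrogen would match compound 3.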